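The source may hold more compounds than are shown below. What is called first, only, known or untested is meant among the compounds shown, and "the series" means these compounds.

In a functional assay on HeLa cells (Homo sapiens) for antiproliferative activity, read by MTT assay, with a stated time of 24 h (a higher number here means a weaker inhibitor, a lower number a stronger inhibitor), three analogues of a shared core were compared, differing only in the aryl group on a saturated chain carbon bound to a sulfur. Compound 1 `COc1cccc(CSc2nnc(-c3ccc4c(c3)OCCO4)n2-c2ccccc2)c1` reaches only the limit of > 100000 nM (the limit of > 100000 nM in this assay, at which 1 of the 3 values shown sits). Compound 2 `Cc1ccc(CSc2nnc(-c3ccc4c(c3)OCCO4)n2-c2ccccc2)cc1` gives 49700 nM, while compound 3 `Fc1ccc(CSc2nnc(-c3ccc4c(c3)OCCO4)n2-c2ccccc2)c(F)c1` gives 18600 nM, the lowest of the two numbers, reached through a 2.7-fold lower number from compound 2 to compound 3 (0.43 log units; beyond the scatter) and an at least 5.3-fold lower number from compound 1 to compound 3 (0.73 log units; beyond the scatter). Compound 4 `Brc1ccccc1CSc1nnc(-c2ccc3c(c2)OCCO3)n1-c1ccccc1` carries 2-bromophenyl in place of 2,4-difluorophenyl on a saturated chain carbon bound to a sulfur. Going by the values given here, the steps that bear on this change are those same two aryl swaps, both modest in size, so the expectation for compound 4 is a step of a 1.2-fold higher number from compound 3 to compound 4 (0.07 log units; within the scatter), staying within the scatter. Compound 4 is therefore estimated to give 22000 nM, in a range from 7000 nM to 70000 nM.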

Compound 4, half-maximal inhibitory concentration: > 100000 nM
Compound 4 ended at the assay's limit; the forecaster's own chance of this, stated with the estimate: 10%; middle value at least 4.5-fold (0.65 log units) away from the limit.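

Compound 4 shows that this position, on a saturated chain carbon bound to a sulfur, can lose activity with a halogen-bearing aryl group, so halogen substitution alone does not preserve the level of compound 3: 2-bromophenyl in place of 2,4-difluorophenyl gives an at least 5.3-fold higher number from compound 3 to compound 4 (0.73 log units; beyond the scatter). Against the 4-methylphenyl analogue, the change gives an at least 2.0-fold higher number from compound 2 to compound 4 (0.30 log units; that floor lies within the scatter). Compound 4, like compound 1, stands at a limit rather than a number, so the step between them cannot be read: the limit of > 100000 nM in this assay, at which 2 of the 4 values shown sit.

This single change replaces both fluorines with one bromine, so it cannot separate the identity of the halogen from the substitution pattern. As far as these compounds go, how a 2-fluorophenyl or 4-bromophenyl group, or an amine on the ring, would behave here remains open.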